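The source may hold more compounds than are shown below. What is called first, only, known or untested is meant among the compounds shown, and "the series" means these compounds.

Compound 1 `C=CCc1ccc(OCc2cn(-c3ccccc3CO)nn2)c(O)c1`: 87.1%
Compound 2 `C=CCc1cc(O)c(O)c(CN2CCC(CO)CC2)c1`: 49.4%
Compound 3 `C=CCc1ccc(OCc2cn(-c3cc(OC)c(OC)c(OC)c3)nn2)c(O)c1`: 55.9%

In a functional assay on SK-N-SH cells (Homo sapiens) for inhibition, read by MTT assay, with a stated time of 72 h, tested at 50 uM (a lower number here means less inhibition of growth, a higher number more inhibition of growth at the concentration tested), compound 2 stands lowest of the three numbers. Compound 3 lies within the scatter of it, so the two cannot be told apart; compound 1 sits well beyond the scatter, clearly higher than compound 2. Compound 4 `C=CCc1cc(O)c(O)c(CN2CCC(CCO)CC2)c1` has not yet been measured. It differs from compound 2 by hydroxymethyl in place of hydroxy on a saturated chain carbon bound to a saturated ring carbon. For the measured compounds named here, no pair of measured compounds shows a change of this kind, so there is no measured step to lean on. The change is a small one at a chain carbon, and no movement beyond the scatter is expected. The expected step is a number 0.6 percentage points higher from compound 2 to compound 4 (within the scatter), not beyond the scatter. For compound 4 the estimate is 50%, ranging from 35% to 65%.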

Compound 4, percent growth inhibition at one concentration: 40.6%
For compound 4 the middle estimate is 9.4 percentage points above the measured one; measured number inside the range.
By their numbers in this assay, from the lowest: compounds 4, 2 and 3 (each within the scatter of the next, the first and the last beyond it); then compound 1.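

In this assay, for the compounds shown here, the change from hydroxymethyl to 2-hydroxyethyl on the saturated ring carbon gives the first measured step at this position: a number 8.8 percentage points lower from compound 2 to compound 4 (within the scatter). Growth inhibition at the concentration tested therefore does not separate these two side chains, and the step gives no sign that this small extension matters here. No available evidence bears on this result. On these data alone, whether a longer chain, an amine or a carboxylic acid in place of the hydroxymethyl would give a step beyond the scatter remains open.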